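This account rests on a few compounds, and the source may have more. Where it says the series, first, only, none or still open, it means among the compounds named here.

Three compounds share a common core and differ only in the group on the aromatic nitrogen. Compound 1 `CC(C)(C)OC(=O)N1CCN(C(=S)SCc2cn(-c3ccccc3F)nn2)CC1` gives 89600 nM in a functional assay on MCF7 cells (Homo sapiens) for inhibition, read by MTT assay, with a stated time of 72 h; on this read-out lower numbers stand for stronger inhibition and higher numbers for weaker inhibition. Compound 3 `Cc1ccc(-n2cc(CSC(=S)N3CCN(C(=O)OC(C)(C)C)CC3)nn2)cc1` gives 74200 nM in this assay. Compound 2 `CC(C)(C)OC(=O)N1CCN(C(=S)SCc2cn(Cc3ccc(Cl)cc3)nn2)CC1` gives 2960 nM in this assay. Compound 2 stands lowest of the three numbers: the nearest is compound 3, with a 25-fold higher number from compound 2 to compound 3 (1.40 log units; beyond the scatter), and the furthest is compound 1, with a 30-fold lower number from compound 1 to compound 2 (1.48 log units; beyond the scatter), while a 1.2-fold lower number from compound 1 to compound 3 (0.08 log units; within the scatter) keeps compound 1 and compound 3 together.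

Compound 4 `O=C(OCc1ccccc1)N1CCN(C(=S)SCc2cn(Cc3ccc(Cl)cc3)nn2)CC1` keeps the 4-chlorobenzyl of compound 2 and alters the carbamate end instead: benzyl in place of tert-butyl on an oxygen next to a carbonyl group, that is tert-butoxycarbonyl to benzyloxycarbonyl. Among the compounds with values here, none of the measured steps touches this part of the molecule; all three vary the group on the aromatic nitrogen, and the tert-butoxycarbonyl is constant across compounds 1, 2 and 3. Within the data shown here, there is thus no measured precedent for the change in compound 4, and the expectation for this assay is a step not beyond the scatter, with no direction preferred and with wide uncertainty. For compound 4 the estimate in this assay is 3000 nM, in the range 900 nM to 10000 nM. The corresponding step is expected to read a 1.0-fold higher number from compound 2 to compound 4 (0.01 log units; within the scatter).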

Compound 4, half-maximal inhibitory concentration: 27500 nM
For compound 4 the middle estimate is 9.2-fold (0.96 log units) below the measured one; the whole stated range lies below it.
By their numbers in this assay, from the lowest: compound 2; then compound 4; then compounds 3 and 1 (each within the scatter of the next).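

The carbamate end is not silent in this assay: with the 4-chlorobenzyl held fixed, benzyl in place of tert-butyl on an oxygen next to a carbonyl group gives a 9.3-fold higher number from compound 2 to compound 4 (0.97 log units; beyond the scatter) in the direction of weaker inhibition, so a part of the molecule that stays constant across compound 1, compound 2 and compound 3 also moves the read-out beyond the scatter. The entering benzyl brings a six-membered aromatic ring of carbon only, which the tert-butyl lacks, while neither group carries hydrogen-bond donors or acceptors, so the step cannot be tied to a difference in those counts. Nothing measured here bears on why the number rises with this change.

As far as these compounds go, the change is seen in a single pair, so whether it reads the same with 2-fluorophenyl or 4-methylphenyl on the aromatic nitrogen stays open. Also open, from the compounds shown here alone, is how the number responds on this oxygen to a methyl, an ethyl or a longer chain ending in an amine, which would show whether tert-butyl is a particularly favourable group here.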